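A few compounds are considered here, and "the series" means these few. Any claim that something is new, unique, unknown or untested is made for them only; others in the source may bear on it.

Two measured compounds frame this account. In a functional assay on PC-9 cells (Homo sapiens) for inhibition, read by MTT assay, with a stated time of 72 h (on this read-out lower numbers stand for stronger inhibition and higher numbers for weaker inhibition), compound 2 `Cc1cc(Nc2cc(-c3ccccc3)[nH]n2)n2nc(SCCc3ccccc3)nc2n1` gives 4930 nM, and compound 1 `Cc1cc(Nc2cc(-c3ccc(Cl)cc3)[nH]n2)n2nc(SCc3ccc(Br)cc3)nc2n1` gives 4920 nM; the two numbers lie within the scatter of each other, so nothing separates them. Compound 3 `COc1ccc(CSc2nc3nc(C)cc(Nc4cc(-c5ccccc5)[nH]n4)n3n2)cc1` is not yet measured. It differs from compound 2 by 4-methoxyphenyl in place of benzyl on a saturated chain carbon bound to a sulfur. Among the measured compounds shown here, no step between measured compounds bears on this change, so compound 3 is expected to land near compound 2, with the step of a 1.1-fold lower number from compound 2 to compound 3 (0.04 log units; within the scatter) in this assay expected to stay within the scatter. Compound 3 is estimated at 4500 nM, between 1800 nM and 11000 nM.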

Compound 3, half-maximal inhibitory concentration: 8110 nM
Compound 3: middle estimate off by 1.8-fold (0.26 log units), on the low side; low and high end bracket the measured number.
By their numbers in this assay, from the lowest: compounds 1, 2 and 3 (each within the scatter of the next).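

In this assay, (4-methoxybenzyl)sulfanyl in place of phenethylsulfanyl gives a 1.6-fold higher number from compound 2 to compound 3 (0.22 log units; within the scatter), the first step read at this position on a saturated chain carbon bound to a sulfur. The step stays within the scatter, so the added methoxy oxygen, counted as a hydrogen-bond acceptor, does not separate compound 3 from compound 2 here. No measurement at hand bears on the reason for this step. Still open, on these data alone, is whether an amine or a carboxylic acid in place of the 4-methoxyphenyl, or a longer chain on the sulfur, would give a number beyond the scatter.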